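This account rests on a few compounds, and the source may have more. Where it says the series, first, only, none or still open, it means among the compounds named here.

Compound 1 `COc1ccc(/C=C2\CN(C(=S)SCc3cn(Cc4ccccc4F)nn3)C/C(=C\c3ccc(OC)cc3)C2=O)cc1`: 49900 nM
Compound 2 `COc1ccc(/C=C2\CN(Cc3cn(Cc4cccc(Cl)c4)nn3)C/C(=C\c3ccc(OC)cc3)C2=O)cc1`: 56600 nM
Compound 3 `O=C1/C(=C/c2ccccc2F)CN(Cc2cn(Cc3cccc(Cl)c3)nn2)C/C1=C\c1ccccc1F`: 6100 nM

All three values come from a functional assay on 4T1 cells (Mus musculus) for cytotoxicity, read by MTT assay, with a stated time of 24 h; a lower number here means a stronger inhibitor, a higher number a weaker inhibitor. Compound 2 stands at the weak end of this small set, within the scatter of compound 1, while compound 3 has a clearly lower number and so is the stronger inhibitor of the two.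

Compound 4 `COc1ccc(/C=C2\CN(Cc3cn(Cc4ccccc4F)nn3)C/C(=C\c3ccc(OC)cc3)C2=O)cc1` differs from compound 2 in a single place: 2-fluorophenyl in place of 3-chlorophenyl on a saturated chain carbon bound to an aromatic nitrogen. In words, it has 2-fluorophenyl in place of 3-chlorophenyl on a saturated chain carbon bound to an aromatic nitrogen, which can also be read as 3-chlorobenzyl to 2-fluorobenzyl.

Going by the values given here, no measured pair shows this change on its own, so the expectation rests on thin evidence. Though it differs from compound 4 elsewhere, compound 1 also carries the 2-fluorobenzyl group, and its value of 49900 nM offers a loose guide. Compound 3 differs from compound 2 elsewhere too, so its lower number says nothing direct about this change. No shift beyond the scatter is expected in this assay. The estimated 1.1-fold lower number from compound 2 to compound 4 (0.05 log units; within the scatter) is therefore small. For compound 4 the expected value is 50000 nM, with an estimated range from 25000 nM to 100000 nM.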

Compound 4, half-maximal inhibitory concentration: 39400 nM
For compound 4 the middle estimate is 1.3-fold (0.10 log units) above the measured one, and the stated range covers the measured number.
By their numbers in this assay, from the lowest: compound 3; then compounds 4, 1 and 2 (each within the scatter of the next).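

In this assay, going by these compounds alone, exchanging 3-chlorobenzyl for 2-fluorobenzyl gives a 1.4-fold lower number from compound 2 to compound 4 (0.16 log units; within the scatter) and offers the first direct reading of this position, since the rest of the molecule stays the same. At this place, on a saturated chain carbon bound to an aromatic nitrogen, one halogen-carrying phenyl ring can therefore stand in for the other without a change that can be told from the scatter of the measurement. Nothing measured here bears on why the two groups read alike, so this result remains an observation without an explanation.

Going by these compounds, the two groups compared are closely related, so the response of this position to something quite different, such as a phenyl ring carrying an amine or a carboxylic acid, or a longer chain in place of the benzyl group, remains open. This single step also comes from the core shared by compound 2 and compound 4, leaving open whether the same exchange would read alike on the core of compound 3.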